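The source may report more compounds than this note shows. Statements on the series, on what has been measured and on what is new or still open speak of the compounds shown alone.

Measured compounds:
- Compound 1 `Nc1ccc(S(=O)(=O)N2CCN(c3ncc(C(O)(C(F)(F)F)C(F)(F)F)cc3Br)CC2)cn1`: in an ADME assay (liver) for metabolic stability, with Liver microsome (Homo sapiens) as the target, using microsomes and NADPH, with a stated time of 30 min, tested at 1 uM (a lower number here means slower removal, a higher number faster removal of the compound), compound 1 gives < 14 mL.min-1.g-1, which is a limit of the assay rather than a number.
- Compound 2 `CC(C)(O)C#Cc1cc(C(O)(C(F)(F)F)C(F)(F)F)cnc1N1CCN(S(=O)(=O)c2ccc(N)nc2)CC1`: in this assay compound 2 gives < 14 mL.min-1.g-1, again a limit of the assay.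
- Compound 3 `Nc1ccc(S(=O)(=O)N2CCN(c3ncc(C(O)(C(F)(F)F)C(F)(F)F)cc3-c3ccncc3)CC2)cn1`: in this assay compound 3 gives 15 mL.min-1.g-1.

Within the data shown here, compound 3 thus holds the only true number among the three, since the other two sit at a limit (the limit of < 14 mL.min-1.g-1 in this assay, at which 2 of the 3 values shown sit). The untested compound 4 `Nc1ccc(S(=O)(=O)N2CCN(c3ncc(C(O)(C(F)(F)F)C(F)(F)F)cc3-c3ccc4ocnc4c3)CC2)cn1` differs from compound 3 in one place: 1,3-benzoxazol-5-yl in place of pyridin-4-yl on an aromatic carbon.

Among the measured compounds shown here, two measured steps touch the same position. The step of an at least 1.0-fold higher number from compound 1 to compound 3 (0.02 log units; that floor lies within the scatter) and the step of an at least 1.0-fold higher number from compound 2 to compound 3 (0.02 log units; that floor lies within the scatter) each introduced pyridin-4-yl, and each is only a floor that lies within the scatter. No measured step exchanges one aromatic ring for another, so the size of this change is not directly shown. The expected step of a 1.5-fold higher number from compound 3 to compound 4 (0.17 log units; within the scatter) is therefore small, with no direction beyond the scatter claimed. Compound 4 is expected to give about 22 mL.min-1.g-1, within a range of 10 mL.min-1.g-1 to 50 mL.min-1.g-1.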

Compound 4, intrinsic clearance in microsomes: < 14 mL.min-1.g-1
Compound 4: a limit, no number; the forecaster's own chance of this, stated with the estimate: 20%; at least 1.5-fold (0.19 log units) between middle value and limit.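

In this assay compound 4 gives < 14 mL.min-1.g-1, which is a limit of the assay and not a number. Among these compounds, the step from one aromatic group to another at this position, on an aromatic carbon two atoms from the ring nitrogen, can now be read for the first time, though only as a floor: an at least 1.0-fold lower number from compound 3 to compound 4 (0.02 log units; that floor lies within the scatter). Exchanging the single ring of pyridin-4-yl for the two rings of 1,3-benzoxazol-5-yl therefore shows no change beyond the scatter, and the series still gathers at one value: the limit of < 14 mL.min-1.g-1 in this assay, at which 3 of the 4 values shown sit.

On these data alone, the steps to compound 4 from compound 1 and from compound 2 join two limits and cannot be read, so the true size of these changes stays open. Also open, as far as these compounds go, is whether a basic amine or a carboxylic acid at this position would give a clearly different number.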